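The source may report more compounds than this note shows. Statements on the series, on what has been measured and on what is new or still open speak of the compounds shown alone.

Compound 1 `O=C(CCCCCCc1ccccc1)c1ncc(-c2cccc(O)c2)o1` gives 50 nM, compound 2 `NS(=O)(=O)c1ccc(-c2cnc(C(=O)CCCCCCc3ccccc3)o2)s1` gives 3 nM and compound 3 `O=C(CCCCCCc1ccccc1)c1ncc(-c2ncccn2)o1` gives 5.3 nM, all in an assay (Rattus norvegicus) for inhibition of Fatty-acid amide hydrolase 1 (Homo sapiens); on this read-out lower numbers stand for stronger inhibition and higher numbers for weaker inhibition.

Compound 3 stands second highest of the three numbers: a 1.8-fold higher number from compound 2 to compound 3 (0.25 log units; within the scatter), whereas a 9.4-fold lower number from compound 1 to compound 3 (0.97 log units; beyond the scatter). Compound 4 `CNC(=O)c1cnc(C(=O)CCCCCCc2ccccc2)o1` differs from compound 3 by methylcarbamoyl in place of pyrimidin-2-yl on an aromatic carbon. The measured steps that bear on this all exchange the group at the same aromatic carbon: a 17-fold lower number from compound 1 to compound 2 (1.22 log units; beyond the scatter), a 9.4-fold lower number from compound 1 to compound 3 (0.97 log units; beyond the scatter) and a 1.8-fold higher number from compound 2 to compound 3 (0.25 log units; within the scatter). Going by the values given here, both aromatic replacements of the hydroxyphenyl lowered the number, while a non-aromatic amide at this carbon has no measured precedent. Compound 4 is therefore expected to move modestly upward, a 2.8-fold higher number from compound 3 to compound 4 (0.45 log units; beyond the scatter). The estimate for compound 4 in this assay is 15 nM, with a range from 4 nM to 60 nM.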

Compound 4, inhibition constant: 7 nM
For compound 4 the middle estimate is 2.1-fold (0.33 log units) above the measured one; the range from low to high includes it.
By their numbers in this assay, from the lowest: compounds 2, 3 and 4 (each within the scatter of the next, the first and the last beyond it); then compound 1.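

In this assay, the carbon next to the ring oxygen tolerates a group with no ring: methylcarbamoyl in place of pyrimidin-2-yl gives a 1.3-fold higher number from compound 3 to compound 4 (0.12 log units; within the scatter), so these compounds do not require an aromatic ring there. The amide also keeps a clear margin over the hydroxyphenyl, with a 7.1-fold lower number from compound 1 to compound 4 (0.85 log units; beyond the scatter), but it trails the sulfamoylthiophene, with a 2.3-fold higher number from compound 2 to compound 4 (0.37 log units; beyond the scatter). Nothing available explains these differences.

The compounds shown leave open whether the amide hydrogen matters, which a dimethylcarbamoyl group would test. Going by these compounds, how a carboxylic acid or a longer chain on the amide nitrogen would read at this carbon also stays open.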